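Swapping phenyl for 4-methylcyclohexyl in a weakly cytotoxic urea

The source may report more compounds than this note shows. Statements on the series, on what has been measured and on what is new or still open speak of the compounds shown alone.

Measured compounds:
compound 1 `Cc1ccc(NC(=O)N(Cc2ccccn2)n2cnnc2)cc1`: 39500 nM
compound 2 `O=C(Nc1ccccc1)N(Cc1ccccn1)n1cnnc1`: > 50000 nM

In a functional assay on MDA-MB-231 cells (Homo sapiens) for cytotoxicity, read by MTT assay, with a stated time of 48 h (a lower number here means a stronger inhibitor, a higher number a weaker inhibitor), compound 1 gives 39500 nM. For compound 2 the result is only a limit of the assay, > 50000 nM. That is the limit of > 50000 nM in this assay, at which 1 of the 2 values shown sits. Among the compounds with values here, the one measured step, an at least 1.2-fold higher number from compound 1 to compound 2 (0.10 log units; that floor lies within the scatter), concerns a methyl elsewhere and does not touch the change now made. Compound 3 `CC1CCC(NC(=O)N(Cc2ccccn2)n2cnnc2)CC1` differs from compound 2 by 4-methylcyclohexyl in place of phenyl on an amide-type nitrogen. Within the data shown here, with no measured step bearing on this change, the expected step is small, an at least 1.1-fold lower number from compound 2 to compound 3 (0.04 log units; that floor lies within the scatter), in no clear direction. Compound 3 is therefore estimated at 45000 nM, within 15000 nM to 150000 nM.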

Compound 3, half-maximal inhibitory concentration: 33200 nM
The estimate for compound 3 lay 1.4-fold (0.13 log units) above the measured number, within the range that was stated.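

Replacing phenyl on the amide-type nitrogen gives an at least 1.5-fold lower number from compound 2 to compound 3 (0.17 log units; that floor lies within the scatter). Compound 2 has only a limit of the assay, not a number: the limit of > 50000 nM in this assay, at which 1 of the 3 values shown sits. The cleaner comparison keeps the methyl: 4-methylcyclohexyl in place of 4-methylphenyl gives a 1.2-fold lower number from compound 1 to compound 3 (0.08 log units; within the scatter), so in this assay these compounds show no separation between the non-aromatic ring and the aromatic ring at this position. As far as these compounds go, whether a plain cyclohexyl, or a ring carrying an amine or a carboxylic acid, would move the number beyond the scatter stays open.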